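This account rests on a few compounds, and the source may have more. Where it says the series, first, only, none or still open, it means among the compounds named here.

Compound 1 `O=[N+]([O-])c1ccc2nn(Cc3ccccc3)c(OCCBr)c2c1`: > 256000 nM (a limit)
Compound 2 `CCOC(=O)CCCOc1c2cc([N+](=O)[O-])ccc2nn1Cc1ccccc1`: > 256000 nM (a limit)

In an ADME assay on L929 cells (Mus musculus) for cytotoxicity, read by resazurin assay, with a stated time of 48 h (on this read-out higher numbers stand for lower toxicity in this test and lower numbers for higher toxicity in this test), compound 2 gives > 256000 nM, which is a limit of the assay and not a number. Compound 1 also gives a limit, > 256000 nM. The evidence so far is therefore (the limit of > 256000 nM in this assay, at which 2 of the 2 values shown sit).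

Compound 3 `O=[N+]([O-])c1ccc2nn(Cc3ccccc3)c(OCCCO)c2c1` has not yet been measured. It differs from compound 2 as follows: hydroxy in place of ethoxycarbonyl on a saturated chain carbon, three bonds along the chain from an oxygen on an aromatic ring. The 3-(ethoxycarbonyl)propyl group thus becomes 3-hydroxypropyl.

Among the compounds with values here, only one measured step bears on this change, and it also replaces a group on a saturated chain carbon. That step is a step that the two limits leave unreadable from compound 1 to compound 2. It gives no size to carry over, so the expectation rests on compound 2 and compound 1 sharing (the limit of > 256000 nM in this assay, at which 2 of the 2 values shown sit). No step beyond the usual scatter is expected in this assay, and another limit is the likeliest result. The expected step is a number no higher from compound 2 to compound 3 (the limit leaves the size open). For compound 3 the estimated value is 256000 nM, with an expected range from 120000 nM to 512000 nM.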

Compound 3, concentration lethal to 50% of the cells: > 256000 nM
Compound 3: only a limit was reported (the forecaster's own chance of this, stated with the estimate: 70%); the middle value sits exactly at the limit.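

Compound 1, compound 2 and compound 3 all give a limit rather than a number in this assay, so no step between them can be read: the limit of > 256000 nM in this assay, at which 3 of the 3 values shown sit.

The compounds shown leave open where their true values lie beyond that limit, and whether bromo, ethoxycarbonyl and hydroxy on the chain differ at all in toxicity to these cells.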